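Phenyl for pyridin-4-yl in a quinolone amide series

The source may hold more compounds than are shown below. What is called first, only, known or untested is meant among the compounds shown, and "the series" means these compounds.

The shared core of compound 1 `Cn1cc(C(=O)Nc2ccc(-c3ccccc3)c(C(F)(F)F)c2)c(=O)c2cnccc21` is tested in an ADME assay on microsomes from liver (Rattus norvegicus) for metabolic stability, with a stated time of 30 min; a lower number here means slower removal, a higher number faster removal of the compound. For compound 1 the reading is only a limit of the assay, < 14 uL/min. Compound 2 `Cn1cc(C(=O)Nc2ccc(-c3ccncc3)c(C(F)(F)F)c2)c(=O)c2ccccc21` gives 44 uL/min in this assay, the only number shown, with the other value sitting at the limit of < 14 uL/min in this assay, at which 1 of the 2 values shown sits. Compound 3 `Cn1cc(C(=O)Nc2ccc(-c3ccccc3)c(C(F)(F)F)c2)c(=O)c2ccccc21` arises from compound 2 by one change: phenyl in place of pyridin-4-yl on an aromatic carbon. For the measured compounds named here, no measured step covers this change, so the account estimates a modest rise beyond the scatter, a 1.5-fold higher number from compound 2 to compound 3 (0.17 log units; within the scatter). Compound 3 is expected to give 65 uL/min in this assay, between 30 uL/min and 140 uL/min.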

Compound 3, intrinsic clearance in a liver preparation (reported as CLH), per the amount of preparation that the assay uses in the Rattus norvegicus assay: < 14 uL/min
Compound 3: a limit, no number; the forecaster's own chance of this, stated with the estimate: 5%; middle value at least 4.6-fold (0.66 log units) from the limit.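

On an aromatic carbon ortho to a trifluoromethyl group, phenyl in place of pyridin-4-yl makes a clear difference in the Rattus norvegicus assay, with an at least 3.1-fold lower number from compound 2 to compound 3 (0.49 log units; beyond the scatter). Compound 3 gives only a limit there, so this step is a bound and not a measured size: the limit of < 14 uL/min in the Rattus norvegicus assay, at which 2 of the 3 values shown sit. In a physicochemical assay for solubility, in simulated intestinal fluid, at pH 7.4 (a higher number here means a more soluble compound, a lower number a less soluble compound), compound 2 gives 12 ug/mL and compound 3 gives 11 ug/mL, two values within the scatter of each other.

The compounds shown leave open whether a different group at this position, such as morpholine or a carboxylic acid, would also reach the limit in the Rattus norvegicus assay.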